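A few compounds are considered here, and "the series" means these few. Any claim that something is new, unique, unknown or untested is made for them only; others in the source may bear on it.

Measured so far:
Compound 1, `COc1cc(/C=C/C(=O)/C=C/c2cc(OC)c(OC)c(OC)c2)ccc1OCc1cn(CCOc2cc(=O)oc3ccccc23)nn1`, gives 86%.
Compound 2, `COc1cc(/C=C/C(=O)/C=C/c2cccc3ccccc23)ccc1OCc1cn(CCCCOc2cc(=O)oc3ccccc23)nn1`, gives 50%.
Compound 3, `COc1ccc(/C=C/C(=O)/C=C/c2ccc(OCc3cn(CCCOc4cc(=O)oc5ccccc45)nn3)c(OC)c2)cc1OC`, gives 65%.

All three were tested in a functional assay on COLO 205 cells (Homo sapiens) for inhibition, read by sulforhodamine B assay, with a stated time of 48 h, tested at 50 uM; on this read-out lower numbers stand for less inhibition of growth and higher numbers for more inhibition of growth at the one concentration tested. On these numbers compound 2 stands lowest: compound 3 lies above it by a margin beyond the scatter, and compound 1 lies further above it, also beyond the scatter. Compound 4, `COc1cccc(/C=C/C(=O)/C=C/c2ccc(OCc3cn(CCCCOc4cc(=O)oc5ccccc45)nn3)c(OC)c2)c1`, has not been measured. It differs from compound 2 in one place: 3-methoxyphenyl in place of naphthalen-1-yl on a double-bonded chain carbon bound to a double-bonded chain carbon. Compounds 1 and 3, which carry methoxy-bearing rings on both arms of the shared core, sit above compound 2, so a small upward step a number 10 percentage points higher from compound 2 to compound 4 (within the scatter) is expected, close to the edge of the scatter. Compound 4 is accordingly estimated at 60%, within a range from 40% to 80%.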

Compound 4, percent growth inhibition at one concentration: 46%
For compound 4 the middle estimate is 14 percentage points above the measured one; low and high end bracket the measured number.
By their numbers in this assay, from the lowest: compounds 4 and 2 (each within the scatter of the next); then compound 3; then compound 1.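

In this assay, placing 3-methoxyphenyl in place of naphthalen-1-yl on a double-bonded chain carbon bound to a double-bonded chain carbon gives a number 4 percentage points lower from compound 2 to compound 4 (within the scatter), the only one-place comparison shown. At this position, the read-out therefore does not separate one aromatic ring bearing a methoxy group from the two aromatic rings of naphthalen-1-yl. Nothing available explains this result. The compounds shown leave open how an amine or a carboxylic acid at this position would read, and whether a longer chain on the triazole would change the number.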